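The source may report more compounds than this note shows. Statements on the series, on what has been measured and on what is new or still open speak of the compounds shown alone.

Measured in an ADME assay on CEM-SS cells (Homo sapiens) for cytotoxicity, read by XTT assay; a lower number here means that less compound is tolerated, a higher number that more compound is tolerated:
- compound 1 (`O=C(NO)c1cc2ccn(Cc3ccc(F)cc3)c2cn1`) gives 159000 nM
- compound 2 (`O=C(NO)c1cc2ccn(Cc3cccc(Cl)c3F)c2cn1`) gives > 320000 nM, a limit
- compound 3 (`O=C(NO)c1cc2ccn(Cc3cccc(Cl)c3Cl)c2cn1`) gives > 320000 nM, a limit

Within the data shown here, compound 1 holds the only number in this set, while compound 2 and compound 3 are reported only as limits. The next change leads to compound 4 (`O=C(NO)c1cc2ccn(Cc3ccccn3)c2cn1`), with pyridin-2-yl in place of 4-fluorophenyl on a saturated chain carbon bound to an aromatic nitrogen. Among the measured compounds shown here, the only measured step between two compounds is a step that the two limits leave unreadable from compound 2 to compound 3, and it is a different change, chloro in place of fluoro on an aromatic carbon. For the measured compounds named here, it gives no size to carry over, and no measured step covers the exchange made here. The expectation in this assay therefore starts from compound 1 at 159000 nM, with no direction favoured and no shift beyond the usual scatter. The expected change is a 1.2-fold higher number from compound 1 to compound 4 (0.08 log units; within the scatter). For compound 4 the estimated value is 190000 nM, with an expected range of 90000 nM to 320000 nM.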

Compound 4, half-maximal cytotoxic concentration: > 10000 nM
Compound 4 ended at the assay's limit; the forecaster's own chance of this, stated with the estimate: 30%; the middle value lies beyond the limit too.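

Among these compounds, compound 4 stands at > 10000 nM as a limit and not a number, so no step from compound 1 to compound 4 can be read. The compounds shown leave open how far, and in which direction, pyridin-2-yl in place of 4-fluorophenyl shifts the tolerated concentration.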